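This account rests on a few compounds, and the source may have more. Where it says the series, first, only, none or still open, it means among the compounds named here.

The set rests on a shared core carrying a varied aryl group. Compound 1 `Cc1cc(-c2cccc(F)c2)c2ncc(CSCCc3ccccc3)n2c1` gives 35 ug/mL in an ADME assay on HEL cells (Homo sapiens) for cytotoxicity, with a stated time of 3 days; on this read-out higher numbers stand for lower toxicity in this test and lower numbers for higher toxicity in this test. Going by the values given here, compound 2 `Cc1cc(-c2ccc(O)cc2)c2ncc(CSCCc3ccccc3)n2c1` gives 13.7 ug/mL in this assay, and the single-point change between the two, a 2.6-fold lower number from compound 1 to compound 2 (0.41 log units; beyond the scatter), is the only measured step. Compound 3 `COc1cccc(-c2cc(C)c3ncc(CSCCc4ccccc4)n3c2)c1` gives 36 ug/mL in this assay, the highest of the three numbers, though its gap to compound 1 lies within the scatter; only compound 2 stands apart from it, beyond the scatter and lower.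

Compound 4 `Cc1cc(-c2cccc(O)c2)cn2c(CSCCc3ccccc3)cnc12` has not yet been measured. Its difference from compound 3 is hydrogen in place of methyl on an oxygen on an aromatic ring, which reads one bond further out as methoxy to hydroxy, or 3-methoxyphenyl to 3-hydroxyphenyl. Among the compounds with values here, no measured pair shows this exact change. The closest guide is a 2.6-fold lower number from compound 1 to compound 2 (0.41 log units; beyond the scatter), where the hydroxy-bearing compound 2 returns the lower number. On that basis a modest downward step is expected for compound 4 in this assay, a 1.6-fold lower number from compound 3 to compound 4 (0.21 log units; within the scatter), with a fair chance of staying within the scatter. Compound 4 is estimated at 22 ug/mL, in a range from 10 ug/mL to 42 ug/mL.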

Compound 4, half-maximal cytotoxic concentration: 50 ug/mL
Compound 4: the middle estimate sits 2.3-fold (0.36 log units) below what was measured; the measured number lies above the stated range.
By their numbers in this assay, from the lowest: compound 2; then compounds 1, 3 and 4 (each within the scatter of the next).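

Replacing methyl with hydrogen on the oxygen of the 3-methoxyphenyl group gives a 1.4-fold higher number from compound 3 to compound 4 (0.14 log units; within the scatter) in this assay, so at this place the change from methoxy to hydroxy leaves the read-out within the scatter. The earlier compounds shown here offered only the hydroxy-bearing compound 2 with a number apart from the rest, whereas compound 4 also carries a hydroxy yet stands with compounds 1 and 3, so a hydroxy on the aryl group does not by itself go with the lower number. Nothing measured here accounts for the difference between these two hydroxy-bearing compounds. The compounds shown leave open whether an amine or a carboxylic acid at this place on the phenyl ring would also stay within the scatter of compound 3 in this assay.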